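A few compounds are considered here, and "the series" means these few. Any claim that something is new, unique, unknown or untested is made for them only; others in the source may bear on it.

Measured so far:
- compound 1, `N[C@H]1CC[C@H](Nc2c(C(=O)NCc3ccc(F)cc3)nc(N3CCCCC3)c3cccnc23)CC1`: 8000 nM
- compound 2, `N[C@H]1CC[C@H](Nc2c(C(=O)NCc3ccco3)nc(Br)c3cccnc23)CC1`: > 10000 nM
- compound 3, `CS(=O)(=O)NCCCCCCN(c1nc(C(=O)NCc2ccc(F)cc2)c(O)c2ncccc12)S(C)(=O)=O`: 3000 nM

In a functional assay on HCT-116 cells (Homo sapiens) for cytotoxicity, read by MTT assay, with a stated time of 72 h (a lower number here means a stronger inhibitor, a higher number a weaker inhibitor), compound 1 gives 8000 nM. Compound 3 gives 3000 nM in this assay. Compound 2 sits at the limit of > 10000 nM in this assay, at which 1 of the 3 values shown sits; its value > 10000 nM is a limit of this assay and not a number, so compound 2 stands at the weak end of what is shown, without a measured figure. Within the data shown here, no pair among the three measured compounds differs in one place only, so no measured step is available, and the two values with numbers, for compound 1 and compound 3, are merely noted side by side.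

Compound 4 is `N[C@H]1CC[C@H](Nc2c(C(=O)NCc3ccccc3)nc(Br)c3cccnc23)CC1`, to be measured in this assay. It differs from compound 2 by phenyl in place of furan-2-yl on a saturated chain carbon bound to an amide-type nitrogen. Among the measured compounds shown here, with compound 2 at a limit, no step in this direction can be sized from the data. The expectation is a step of little or no size beyond the scatter, given as a step that the limit leaves unreadable from compound 2 to compound 4, and compound 4 is expected to give 12000 nM, in a range from 4000 nM to 40000 nM, with a fair chance that only a limit is again reported.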

Compound 4, half-maximal inhibitory concentration: 7000 nM
Compound 4: the middle estimate sits 1.7-fold (0.23 log units) above what was measured; low and high end bracket the measured number.
By their numbers in this assay, from the lowest: compound 3; then compounds 4 and 1 (each within the scatter of the next). At a limit, above all of these: compound 2.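

In this assay, among these compounds, phenyl in place of furan-2-yl on a saturated chain carbon bound to an amide-type nitrogen gives the only step that can be sized, an at least 1.4-fold lower number from compound 2 to compound 4 (0.15 log units; that floor lies within the scatter). Going by these compounds, compound 2 is held at a limit and has no measured number, so this step is a floor and its true size stays unknown: the limit of > 10000 nM in this assay, at which 1 of the 4 values shown sits. Compound 4 gives 7000 nM as a measured number, which shows that with phenyl at this place the compound reads within the range of the assay.

On these data alone, how far the number moves with other groups at this place stays open, for example with a cyclohexyl ring in place of phenyl, or with an amine or a carboxylic acid on the phenyl ring. As far as these compounds go, whether the step carries over to other substituents on the shared core also stays open.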